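From 2-fluorophenyl to 4-methoxyphenyl on a shared core

This account rests on a few compounds, and the source may have more. Where it says the series, first, only, none or still open, it means among the compounds named here.

In a functional assay on HL-60 cells (Homo sapiens) for inhibition, read by MTT assay, with a stated time of 72 h (a higher number here means a weaker inhibitor, a lower number a stronger inhibitor), compound 1 `CCc1nc(-c2ccccc2F)c(C(=O)N2CCN(c3cccc(Cl)c3)CC2)o1` gives 139 nM and holds the higher of the two numbers available. Compound 3 `Cc1ccc(C)c(N2CCN(C(=O)c3oc(C)nc3-c3ccccc3)CC2)c1` gives 31.3 nM and so sits lower, by more than the usual scatter. Compound 2 `O=C(c1oc(C(F)(F)F)nc1-c1ccccc1F)N1CCN(c2cccc(Cl)c2)CC1` is recorded as "not active" (no number reported) and has no number at all.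

Compound 4 `CCc1nc(-c2ccc(OC)cc2)c(C(=O)N2CCN(c3cccc(Cl)c3)CC2)o1` carries 4-methoxyphenyl in place of the 2-fluorophenyl of compound 1 on an aromatic carbon (4-methoxyphenyl in place of 2-fluorophenyl on an aromatic carbon). Going by the values given here, no measured pair isolates this change, so the expectation starts from compound 1 (139 nM) and foresees no step beyond the scatter in this assay in either direction. The estimated step (a 1.2-fold lower number from compound 1 to compound 4 (0.06 log units; within the scatter)) is expected to stay small. For compound 4 the expected value is 120 nM with an estimated range from 30 nM to 500 nM for the measurement.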

Compound 4, half-maximal inhibitory concentration: > 1000 nM
Compound 4: only a limit was reported; the forecaster's own chance of this, stated with the estimate: 15%; middle value at least 8.3-fold (0.92 log units) from the limit.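

On the core of compound 1, the aromatic carbon next to the ring nitrogen proves sensitive to the group it carries: in this assay, 4-methoxyphenyl in place of 2-fluorophenyl gives an at least 7.1-fold higher number from compound 1 to compound 4 (0.85 log units; beyond the scatter). Going by these compounds alone, the earlier compounds offered no step at this position, so this is the first reading of it. The reading for compound 4 is only a limit: the limit of > 1000 nM in this assay, at which 1 of the 4 values shown sits.

As far as these compounds go, it remains open whether the change in the number follows from the loss of the fluorine or from the methoxy group and where it sits. A 4-fluorophenyl or a 2-methoxyphenyl at this position would separate the two.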